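Swapping the aryl group on a tricyclic ketone for an anilino group

The source may hold more compounds than are shown below. What is called first, only, known or untested is meant among the compounds shown, and "the series" means these compounds.

Measured compounds in a functional assay on A549 cells (Homo sapiens) for antiproliferative activity, read by MTT assay, with a stated time of 72 h; on this read-out higher numbers stand for weaker inhibition and lower numbers for stronger inhibition:
- compound 1 `COc1cc(C(=O)c2sc3ccccc3c2-c2ccc(C)cc2)cc(OC)c1OC` gives 7800 nM
- compound 2 `COc1ccc(-c2c(C(=O)c3cc(OC)c(OC)c(OC)c3)sc3ccccc23)c(OC)c1` gives 5800 nM
- compound 3 `COc1cc(C(=O)c2sc3ccccc3c2Nc2ccccc2)cc(OC)c1OC` gives 3000 nM

Compound 1 has the highest number of the three, so it is the weakest inhibitor shown. Compound 2 sits nearest to it, a 1.3-fold lower number from compound 1 to compound 2 (0.13 log units; within the scatter), and compound 3 furthest, a 2.6-fold lower number from compound 1 to compound 3 (0.41 log units; beyond the scatter). Between the other two, a 1.9-fold lower number from compound 2 to compound 3 (0.29 log units; within the scatter).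

Compound 4 `COc1ccc(Nc2c(C(=O)c3cc(OC)c(OC)c(OC)c3)sc3ccccc23)cc1` is the next step from compound 1: (4-methoxyphenyl)amino in place of 4-methylphenyl on an aromatic carbon. Within the data shown here, two measured steps bear on it. The closest is the step to compound 3, where an anilino in place of 4-methylphenyl gave a 2.6-fold lower number from compound 1 to compound 3 (0.41 log units; beyond the scatter), a modest gain. The step to compound 2, where methoxy groups were added to the aryl ring, gave a 1.3-fold lower number from compound 1 to compound 2 (0.13 log units; within the scatter), so adding a methoxy alone changes little. Compound 4 is therefore expected to behave much like compound 3, with a modestly lower number than compound 1, estimated as a 2.8-fold lower number from compound 1 to compound 4 (0.44 log units; beyond the scatter). The estimate for compound 4 in this assay is 2800 nM, within 1000 nM to 7500 nM.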

Compound 4, half-maximal inhibitory concentration: 9300 nM
Compound 4: middle estimate off by 3.3-fold (0.52 log units), on the low side; measured number outside the range, above it.
By their numbers in this assay, from the lowest: compounds 3, 2, 1 and 4 (each within the scatter of the next, the first and the last beyond it).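

Adding one methoxy to the anilino group, in place of hydrogen on an aromatic carbon, gives a 3.1-fold higher number from compound 3 to compound 4 (0.49 log units; beyond the scatter) in this assay, so the modest advantage of the unsubstituted anilino group does not survive this small addition. With that methoxy in place, the nitrogen-linked group can no longer be told apart from either aryl group joined directly to the core: a 1.2-fold higher number from compound 1 to compound 4 (0.08 log units; within the scatter) and a 1.6-fold higher number from compound 2 to compound 4 (0.21 log units; within the scatter) both lie within the scatter. The anilino group's benefit at this position therefore depends on what that group carries, and no data here offer an explanation for the effect of the methoxy.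

From the compounds shown here alone, whether this result is specific to methoxy remains open, as a chlorine, methyl or hydroxyl in its place could behave differently. Also open, going by these compounds, is what a methyl in place of the amine hydrogen would do.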